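Swapping the Amide Aryl on the Best Sulfonamide

A few compounds are considered here, and "the series" means these few. Any claim that something is new, unique, unknown or untested is made for them only; others in the source may bear on it.

Three sulfonamide-amide compounds have been measured in an assay on MDA-MB-231 cells for displacement of a labelled ligand from C-X-C chemokine receptor type 4 (Homo sapiens), read by fluorescence and microscopy, with stated times of 10 min and 30 min; on this read-out lower numbers stand for an effect already at smaller amounts and higher numbers for an effect only at larger amounts of compound. Compound 1 `O=C(NCc1ccc(CNS(=O)(=O)c2cccc(F)c2)cc1)c1cccnc1` gives 1000 nM. Compound 2 `O=C(NCc1ccc(CNS(=O)(=O)c2ccc([N+](=O)[O-])cc2)cc1)c1cccnc1` gives 100 nM, and compound 3 `O=C(NCc1ccc(CNS(=O)(=O)c2cccc3ccccc23)cc1)c1cccnc1` gives 1000 nM. Compound 2 stands at the lowest of the three numbers: the step of a 10-fold lower number from compound 1 to compound 2 (1.00 log units; beyond the scatter) and the step of a 10-fold higher number from compound 2 to compound 3 (1.00 log units; beyond the scatter) both set it apart from the other two, while no change at the digits printed from compound 1 to compound 3 (within the scatter).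

Compound 4 `COc1ccccc1C(=O)NCc1ccc(CNS(=O)(=O)c2ccc([N+](=O)[O-])cc2)cc1` differs from compound 2 at the other end of the shared core: 2-methoxyphenyl in place of pyridin-3-yl on a carbonyl carbon. Within the data shown here, none of the measured steps touches this carbonyl position; all three concern the group on the sulfonyl sulfur. Among the measured compounds shown here, the data therefore hold no step that bears directly on this change, and the expectation rests on compound 2 alone. With nothing shown that would move the number, compound 4 is expected to give 150 nM, within 50 nM to 500 nM, which means an estimated step of a 1.5-fold higher number from compound 2 to compound 4 (0.18 log units; within the scatter) that would sit inside the scatter of repeated measurements.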

Compound 4, effective concentration (reported as EC, without a stated level of effect): 100 nM
For compound 4 the middle estimate is 1.5-fold (0.18 log units) above the measured one, and the stated range covers the measured number.
By their numbers in this assay, from the lowest: compounds 2 and 4 (each within the scatter of the next); then compounds 1 and 3 (each within the scatter of the next).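

In this assay the carbonyl position now has a step of its own, whereas all earlier steps concerned the group on the sulfonyl sulfur: no change at the digits printed from compound 2 to compound 4 (within the scatter), with 2-methoxyphenyl in place of pyridin-3-yl. In this one pair, with 4-nitrophenyl on the sulfonyl sulfur, the ring nitrogen of pyridin-3-yl is thus not needed to keep the number, and a carbon-only ring carrying a methoxy group serves equally within the scatter. No measurement shown here accounts for why the two groups give the same number.

Going by these compounds, whether the same swap would leave the number unchanged with 3-fluorophenyl or naphthalen-1-yl on the sulfonyl sulfur remains open. So does what a piperidine, a cyclohexyl group or a benzoic acid would do on the carbonyl carbon in place of these two aromatic rings.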